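A few compounds are considered here, and "the series" means these few. Any claim that something is new, unique, unknown or untested is made for them only; others in the source may bear on it.

Measured so far in an ADME assay on MDCK cells (Canis lupus familiaris) for cytotoxicity, read by microscopy, with a stated time of 48 h; a higher number here means that more compound is tolerated, a lower number that less compound is tolerated:
Compound 1 `C[C@H]1[C@H](NCc2sccc2-c2ccsc2)C[C@H]2C[C@@H]1C2(C)C` gives 12500 nM.
Compound 3 `C[C@H]1[C@H](NCc2sccc2C2CCCCC2)C[C@H]2C[C@@H]1C2(C)C` gives 1560 nM.
Compound 2 `C[C@H]1[C@H](NCc2ccoc2)C[C@H]2C[C@@H]1C2(C)C` gives only a limit of the assay, > 100000 nM.

Compound 2 therefore stands at the upper edge of the numbers shown, where its value is a limit and not a number (the limit of > 100000 nM in this assay, at which 1 of the 3 values shown sits). The step to compound 4 `C[C@H]1[C@H](NCc2cc(Br)cs2)C[C@H]2C[C@@H]1C2(C)C` changes the structure as follows: 4-bromothiophen-2-yl in place of furan-3-yl on a saturated chain carbon bound to an amine nitrogen. For the measured compounds named here, no measured step makes this exchange. Going by the values given here, the only measured step, an 8.0-fold lower number from compound 1 to compound 3 (0.90 log units; beyond the scatter), swaps one group for another on an aromatic carbon rather than on the saturated chain carbon bound to the amine nitrogen, so it offers no direct guide. Compound 1 and compound 3 both sit at numbers rather than at a limit, so compound 4 is expected to return a number too, with an expected step of an at least 4.0-fold lower number from compound 2 to compound 4 (0.60 log units; beyond the scatter). Compound 4 is estimated at 25000 nM, between 5000 nM and 100000 nM.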

Compound 4, minimum cytotoxic concentration: 6250 nM
Compound 4: the middle estimate sits 4.0-fold (0.60 log units) above what was measured; measured number inside the range.
By their numbers in this assay, from the lowest: compound 3; then compounds 4 and 1 (each within the scatter of the next). At a limit, above all of these: compound 2.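

In this assay, putting 4-bromothiophen-2-yl in place of furan-3-yl on a saturated chain carbon bound to an amine nitrogen gives an at least 16-fold lower number from compound 2 to compound 4 (1.20 log units; beyond the scatter). This shows that the group at this place alone can carry the series from a limit down to a number, which the step on an aromatic carbon could not show. Compound 2 stands at a limit of the assay and not at a number: the limit of > 100000 nM in this assay, at which 1 of the 4 values shown sits.

As far as these compounds go, the bromine and the exchange of ring oxygen for sulfur arrive together in this step, so their separate shares stay open. From the compounds shown here alone, how a ring carrying a carboxylic acid or an amine would behave at this place also stays open.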